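The compounds below may be only part of what the source reports. "The series", "measured", "known", "first", "only" and "open" are said of these compounds alone.

Compound 1 `CC1=CC[C@H](C(C)C)c2cc(C)c(OC(=O)c3ccc(C)cc3)cc21` in a functional assay on U-251 cells (Homo sapiens) for antiproliferative activity, read by sulforhodamine B assay, with a stated time of 48 h, tested at 50 uM; on this read-out higher numbers stand for more inhibition at the one concentration tested (going by the name of the read-out) and lower numbers for less inhibition: 67.7%
Compound 2 `Cc1cc2c(C(C)C)ccc(C)c2cc1OC(=O)c1ccc(C(F)(F)F)cc1` in this assay: 16.5%

Of these two numbers, compound 2 stands lowest; the nearest is compound 1, which sits higher by a margin beyond the scatter. As the two structures differ in more than one place, that gap is taken only as what the two values show. Compound 3 `COc1ccc(C(=O)Oc2cc3c(C)ccc(C(C)C)c3cc2C)cc1` has not yet been measured in this assay. It differs from compound 2 by methoxy in place of trifluoromethyl on an aromatic carbon. For the measured compounds named here, no measured pair shows this change, so the step is expected to be a modest rise, a number 13.5 percentage points higher from compound 2 to compound 3 (beyond the scatter). Compound 3 is therefore expected to give 30%, between 10% and 55%.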

Compound 3, a percentage reported as inhibition, at one concentration (the size of the read-out at that concentration, not a potency): 42.6%
Estimate against measurement, compound 3: 12.6 percentage points below, and the stated range covers the measured number.
By their numbers in this assay, from the lowest: compound 2; then compound 3; then compound 1.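

On the aromatic carbon para to a large group, methoxy in place of trifluoromethyl gives a number 26.1 percentage points higher from compound 2 to compound 3 (beyond the scatter) in this assay and so shows that the read-out responds to the group at this position. For the compounds shown here, this is the first pair differing in one place only, which makes it the first change here that can be read on its own. No measurement shown accounts for this step. As far as these compounds go, how an amine or a carboxylic acid at this position would read stays open. From the compounds shown here alone, whether the step carries over to the core of compound 1 also stays open.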